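The source may hold more compounds than are shown below. What is called first, only, known or untested is meant among the compounds shown, and "the series" means these compounds.

Working notes on the series. The shared core is carried by compound 1 `CC(C)[C@H](NC(=O)COc1cccc2ccccc12)C(=O)N[C@@H](CC(=O)O)C(=O)COc1cc(C(F)(F)F)n(C)n1`, compound 2 `CC(C)[C@H](NC(=O)COc1cccc2ccccc12)C(=O)N[C@@H](CC(=O)O)C(=O)CSc1nnnn1-c1ccccc1` and compound 3 `CC(C)[C@H](NC(=O)COc1cccc2ccccc12)C(=O)N[C@@H](CC(=O)O)C(=O)CSc1nc2ccccc2o1`; the three differ only in the group on the saturated chain carbon bound to the carbonyl carbon. In a functional assay on Jurkat cells (Homo sapiens) for inhibition (a higher number here means a weaker inhibitor, a lower number a stronger inhibitor), compound 1 gives 46000 nM. In this assay compound 2 gives 153000 nM, a step of a 3.3-fold higher number from compound 1 to compound 2 (0.52 log units; beyond the scatter). For compound 3 this assay reports only a limit, > 200000 nM. Compound 3 thus stands at the limit of > 200000 nM in this assay, at which 1 of the 3 values shown sits, and the steps of an at least 4.3-fold higher number from compound 1 to compound 3 (0.63 log units; beyond the scatter) and an at least 1.3-fold higher number from compound 2 to compound 3 (0.11 log units; that floor lies within the scatter) are known only as floors; the second floor does not separate compound 2 from compound 3 beyond the scatter.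

Compound 4 `CC(C)[C@H](NC(=O)COc1cccc2ccccc12)C(=O)N[C@@H](CC(=O)O)C(=O)CSc1nc2ccccc2[nH]1` differs from compound 3 by 1H-benzimidazol-2-yl in place of 1,3-benzoxazol-2-yl on a sulfur. Within the data shown here, the measured steps that bear on this change are an at least 4.3-fold higher number from compound 1 to compound 3 (0.63 log units; beyond the scatter) and an at least 1.3-fold higher number from compound 2 to compound 3 (0.11 log units; that floor lies within the scatter); both lead into the benzoxazole and neither swaps one fused bicycle for another, so the direction of the present change has no measured counterpart. In this assay the expected step is a number no higher from compound 3 to compound 4 (the limit leaves the size open), that is, no step beyond the scatter. Compound 4 is estimated at 200000 nM in this assay, with a range from 60000 nM to 600000 nM, and with a real chance that only a limit is reported again.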

Compound 4, half-maximal inhibitory concentration: > 200000 nM
Compound 4: a limit, no number; the forecaster's own chance of this, stated with the estimate: 55%; the middle value sits exactly at the limit.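

In this assay compound 4 is reported only as a limit, > 200000 nM, so the hydrogen-bond donor that enters with 1H-benzimidazol-2-yl does not bring a readable number at this position on the sulfur. Against the two measured compounds the result gives an at least 4.3-fold higher number from compound 1 to compound 4 (0.63 log units; beyond the scatter), which places the (1H-benzimidazol-2-yl)sulfanyl group with (1,3-benzoxazol-2-yl)sulfanyl on that floor, while an at least 1.3-fold higher number from compound 2 to compound 4 (0.11 log units; that floor lies within the scatter) does not separate the 1H-benzimidazol-2-yl from the 1-phenyl-1H-tetrazol-5-yl group. The step between the two limit compounds cannot be read, and any real difference between 1,3-benzoxazol-2-yl and 1H-benzimidazol-2-yl stays hidden: the limit of > 200000 nM in this assay, at which 2 of the 4 values shown sit.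

Open is whether the lower number of compound 1 follows the oxygen link or the (1-methyl-5-(trifluoromethyl)-1H-pyrazol-3-yl) ring, since the compounds shown change both together. A (1H-benzimidazol-2-yl)oxy group on the same saturated chain carbon, or a 1-methyl-1H-imidazol-2-yl group on the sulfur, would bear on that question and on whether this position can give a number clear of the limit.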